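Swapping an Amine Side Chain on Two Related Cores

The compounds below may be only part of what the source reports. "The series", "measured", "known", "first", "only" and "open" are said of these compounds alone.

Compound 1 `CCNCC(=O)Nc1cc(OC)ccc1C(=O)c1ccc(OC)c2c1C=CC(C)(C)O2` and compound 2 `COc1ccc(C(=O)c2ccc(OC)c3c2C=CC(C)(C)O3)c(NC(=O)CN(C)C)c1` share one core and differ in a single place. In a functional assay on A549 cells (Homo sapiens) for antiproliferative activity, read by MTT assay, with a stated time of 48 h (a higher number here means a weaker inhibitor, a lower number a stronger inhibitor), compound 1 gives 2310 nM. In this assay compound 2 gives 1850 nM. The change between them is dimethylamino in place of ethylamino on a saturated chain carbon bound to a carbonyl carbon, and it made a step of a 1.2-fold lower number from compound 1 to compound 2 (0.10 log units; within the scatter), so the two compounds cannot be told apart by this measurement.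

Compound 3 `C=C(c1ccc2c(c1)C=CC(C)(C)O2)c1ccc(OC)cc1NC(=O)CNCC` is built on a different core; the difference between the two cores is not broken down here. In this assay compound 3 gives 1180 nM. Its partner, compound 4 `C=C(c1ccc2c(c1)C=CC(C)(C)O2)c1ccc(OC)cc1NC(=O)CN(C)C`, has not yet been measured in this assay. It differs from compound 3 by dimethylamino in place of ethylamino on a saturated chain carbon bound to a carbonyl carbon, which is the same change seen between compound 1 and compound 2, made at the same kind of position.

Because the step from compound 1 to compound 2 was a 1.2-fold lower number from compound 1 to compound 2 (0.10 log units; within the scatter), the expectation is that the step from compound 3 to compound 4 in this assay will be similarly small, about a 1.2-fold lower number from compound 3 to compound 4 (0.07 log units; within the scatter), resting on a single earlier example. For compound 4 the estimated value in this assay is 1000 nM, with a likely range from 500 nM to 2000 nM, reflecting the ordinary spread of such measurements on top of one precedent.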

Compound 4, half-maximal inhibitory concentration: 430 nM
Compound 4: the middle estimate sits 2.3-fold (0.37 log units) above what was measured, outside the stated range (below it).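

In this assay, putting dimethylamino in place of ethylamino gave a 2.7-fold lower number from compound 3 to compound 4 (0.44 log units; beyond the scatter), a modest step that stands clear of the usual scatter, whereas the same change on the core of compound 1 could not be told from no change at all. Set side by side, the two steps are no further apart than repeated measurements could place them: the same change on two cores in this assay, a 1.2-fold lower number (0.10 log units; within the scatter) from compound 1 to compound 2 and a 2.7-fold lower number (0.44 log units; beyond the scatter) from compound 3 to compound 4, 2.2-fold (0.34 log units) apart, within the scatter of two such steps The larger step therefore cannot be read as a real difference between the two cores, yet two pairs do not prove that the change behaves the same way on both, and they give no firm size for it on any core in this series.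

The compounds shown leave open whether other groups in the same place on the chain, such as diethylamino or an unsubstituted primary amine, would give steps of a similar size on these two cores. They also leave open whether a longer chain between the amine and the carbonyl would keep the same pattern, and whether the swap from ethylamino to dimethylamino would give a step of similar size on a third core.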